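A few compounds are considered here, and "the series" means these few. Any claim that something is new, unique, unknown or untested is made for them only; others in the source may bear on it.

Measured in a functional assay on MDA-MB-231 cells (Homo sapiens) for antiproliferative activity, read by CCK-8 assay, with a stated time of 48 h (on this read-out higher numbers stand for weaker inhibition and lower numbers for stronger inhibition), so far:
- compound 1 `O=C(/C=C/CNCCOc1ccc(Oc2c(-c3ccc(F)cc3)sc3cc(O)ccc23)cc1)N1CCCC1` gives > 50000 nM (a limit)
- compound 2 `C/C=C/C(=O)N1CC(Oc2ccc(Oc3c(-c4ccc(F)cc4)sc4cc(O)ccc34)cc2)C1` gives > 50000 nM (a limit)
- compound 3 `O=C(CCCNCCOc1ccc(Oc2c(-c3ccc(F)cc3)sc3cc(O)ccc23)cc1)N1CCC1` gives > 50000 nM (a limit)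

Not yet measured: compound 4 `C/C=C/C(=O)NCCOc1ccc(Oc2c(-c3ccc(F)cc3)sc3cc(O)ccc23)cc1`

In this assay compound 3 stands at > 50000 nM as a limit and not a number. The series as a whole shows the limit of > 50000 nM in this assay, at which 3 of the 3 values shown sit, and so offers no ranking.

The change to compound 4 is (prop-1-en-1-yl)carbonyl in place of 3-((azetidin-1-yl)carbonyl)propyl on an amine nitrogen and amounts to (prop-1-en-1-yl)carbonyl in place of 3-((azetidin-1-yl)carbonyl)propyl on an amine nitrogen.

For the measured compounds named here, two measured steps bear on it, namely a step that the two limits leave unreadable from compound 1 to compound 3 and a step that the two limits leave unreadable from compound 2 to compound 3 and neither has a size to carry over. Compound 2 also holds a (prop-1-en-1-yl)carbonyl group and sits at > 50000 nM as a limit, so no gain is expected for compound 4 from that group.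

The expected change is a number no higher from compound 3 to compound 4 (the limit leaves the size open) and no direction is expected for it in this assay beyond the scatter. For compound 4 the estimate is 50000 nM with an expected range from 20000 nM to 100000 nM and a report as a limit is the likeliest outcome.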

Compound 4, half-maximal inhibitory concentration: > 50000 nM
Compound 4 was reported as a limit (the forecaster's own chance of this, stated with the estimate: 75%); the middle value lies on the limit itself.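

In this assay compound 4 gives > 50000 nM as a limit and not a number, so its steps from compound 1, compound 2 and compound 3 cannot be read. The compounds shown leave open how any of them ranks, since all sit at one limit: the limit of > 50000 nM in this assay, at which 4 of the 4 values shown sit.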